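Swapping the ring substituent on a triazole nitrogen: compound 4

The source may report more compounds than this note shows. Statements on the series, on what has been measured and on what is new or still open speak of the compounds shown alone.

Three close relatives share one core and differ only in the group on the ring attached to a triazole nitrogen. Compound 1 `Oc1cc(C(F)(F)F)ccc1-c1nc(-c2ccccc2O)n(-c2ccc(Br)cc2)n1` was tested in a functional assay on PC-12 cells (Rattus norvegicus) for cytotoxicity, read by MTT assay, with stated times of 2 h and 24 h, tested at 5 uM (a lower number here means a weaker effect, a higher number a stronger effect of the compound at the concentration tested), and gives 89.8%. Compound 2 `Oc1cc(C(F)(F)F)ccc1-c1nc(-c2ccccc2O)n(-c2ccc(C(F)(F)F)cc2)n1` gives 90.5%, and compound 3 `Oc1cc(C(F)(F)F)ccc1-c1nc(-c2ccccc2O)n(-c2ccc(OC(F)(F)F)cc2)n1` gives 84.9%. Compound 3 has the smallest of the three numbers, yet the gap to compound 1, a number 4.9 percentage points lower from compound 1 to compound 3 (within the scatter), and the gap to compound 2, a number 5.6 percentage points lower from compound 2 to compound 3 (within the scatter), are both within the scatter, so the three compounds cannot be told apart on these data. The third step, a number 0.7 percentage points higher from compound 1 to compound 2 (within the scatter), is also within the scatter.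

Compound 4 `Oc1cc(C(F)(F)F)ccc1-c1nc(-c2ccccc2O)n(-c2ccccc2F)n1` has not been measured yet. It differs from compound 3 by one change: 2-fluorophenyl in place of 4-(trifluoromethoxy)phenyl on an aromatic nitrogen. All three measured steps exchange the group on the same phenyl ring, and none of them moved the number beyond the scatter. For the measured compounds named here, they bear on the new step only loosely, since in compound 4 the group changes its kind and its place on that ring, which no measured pair covers. With nothing pointing to a shift in either direction, the step from compound 3 to compound 4 is expected to be a number 2.1 percentage points higher from compound 3 to compound 4 (within the scatter). Compound 4 is therefore estimated to give about 87%, within a range from 74% to 96%.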

Compound 4, a percentage reported as activity, at one concentration (the size of the read-out at that concentration, not a potency): 86.6%
For compound 4 the middle estimate is 0.4 percentage points above the measured one, and the stated range covers the measured number.
By their numbers in this assay, from the lowest: compounds 3, 4, 1 and 2 (each within the scatter of the next).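

The earlier compounds shown here vary only the group on a phenyl ring that keeps the 4-position name: 4-bromophenyl, 4-(trifluoromethyl)phenyl and 4-(trifluoromethoxy)phenyl. Compound 4 instead places 2-fluorophenyl on the aromatic nitrogen, so both the kind of group and its place on the ring differ, and the new group has fewer heavy atoms than the 4-(trifluoromethoxy)phenyl it replaces. In this assay this gives a number 1.7 percentage points higher from compound 3 to compound 4 (within the scatter) for that exchange, a number 3.9 percentage points lower from compound 2 to compound 4 (within the scatter) against the 4-(trifluoromethyl)phenyl compound and a number 3.2 percentage points lower from compound 1 to compound 4 (within the scatter) against the 4-bromophenyl compound, so this read-out, at the one concentration tested, separates none of the four groups on this nitrogen, and nothing available explains why.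

As far as these compounds go, all four compounds still carry fluorine or bromine on this phenyl ring, so it remains open whether an amine or a carboxylic acid there, or a longer alkyl chain in place of the ring, would also stay within the scatter. The 2-hydroxyphenyl and 2-hydroxy-4-(trifluoromethyl)phenyl groups are the same throughout, which leaves their share in the read-out open as well.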